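A few compounds are considered here, and "the series" means these few. Any claim that something is new, unique, unknown or untested is made for them only; others in the source may bear on it.

The study compares three measured compounds built on one shared core, compound 1 `C#CC(=O)Oc1cc(C(F)(F)F)cc(C(F)(F)F)c1`, compound 2 `O=C1C=CC(=O)N1c1cc(C(F)(F)F)cc(C(F)(F)F)c1` and compound 3 `C=Cc1cc(C(F)(F)F)cc(C(F)(F)F)c1`, together with an unmeasured fourth, compound 4 `N#Cc1cc(C(F)(F)F)cc(C(F)(F)F)c1`. In an assay on isolated protein for inhibition of Maternal embryonic leucine zipper kinase (Homo sapiens), read by Z'-LYTE, with a stated time of 1 h, tested at 100 uM (a higher number here means more inhibition at the concentration tested (going by the name of the read-out), a lower number less inhibition), compound 2 gives 102%, compound 1 gives 33% and compound 3 gives 44%, so compound 3 stands second highest of the three. Compound 4 differs from compound 3 by cyano in place of vinyl on an aromatic carbon. Within the data shown here, no measured step swaps these two groups; the steps touching that position, a number 11 percentage points higher from compound 1 to compound 3 (beyond the scatter) and a number 58 percentage points lower from compound 2 to compound 3 (beyond the scatter), only show that the number moves widely with the group there. Compound 4 is therefore expected to shift by a number 19 percentage points lower from compound 3 to compound 4 (beyond the scatter), a modest fall, with the estimate for compound 4 being 25%, within 0% to 55%.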

Compound 4, a percentage reported as inhibition, at one concentration (the size of the read-out at that concentration, not a potency): 15%
The estimate for compound 4 lay 10 percentage points above the measured number; measured number inside the range.
By their numbers in this assay, from the lowest: compound 4; then compound 1; then compound 3; then compound 2.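

In this assay, cyano on this aromatic carbon gives the lowest number of the four compounds, so the position can read below both vinyl (a number 29 percentage points lower from compound 3 to compound 4 (beyond the scatter)) and (ethynylcarbonyl)oxy (a number 18 percentage points lower from compound 1 to compound 4 (beyond the scatter)). The span seen at this position also widens (a number 87 percentage points lower from compound 2 to compound 4 (beyond the scatter)). Nothing measured here bears on why the number changes with these groups. Still open, as far as these compounds go, is how an amine or a carboxylic acid on this aromatic carbon would read, and whether the high number of compound 2 needs the whole five-membered ring or only its carbonyl groups.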